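Ethyl in place of phenyl on the isoxazole-bearing core

This account rests on a few compounds, and the source may have more. Where it says the series, first, only, none or still open, it means among the compounds named here.

Compound 1 `Nc1ncnc2c1c(-c1cc(C3CC3)on1)nn2C1CCCCC1` gives 290 nM in an assay on TT cells for inhibition of proto-oncogene tyrosine-protein kinase receptor Ret variant C634W (Homo sapiens), read by MTT assay, with a stated time of 10 days; a higher number here means a weaker inhibitor of growth, a lower number a stronger inhibitor of growth. Compound 2 `CC(C)n1nc(-c2cc(-c3ccccc3)on2)c2c(N)ncnc21` reaches only the limit of the assay there, > 10000 nM, so its potency is not known as a number; it sits at the limit of > 10000 nM in this assay, at which 1 of the 2 values shown sits. Compound 3 `CCc1cc(-c2nn(C(C)C)c3ncnc(N)c23)no1` differs from compound 2 by ethyl in place of phenyl on an aromatic carbon. Within the data shown here, no measured pair of compounds covers this change, so its size in this assay is not established; a move toward stronger inhibition of growth is expected, since the small ring of compound 1 goes with 290 nM. Compound 3 is therefore estimated at 1500 nM, within 300 nM to 8000 nM, a step of an at least 6.6-fold lower number from compound 2 to compound 3 (0.82 log units; beyond the scatter).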

Compound 3, concentration for 50% growth inhibition: 2610 nM
Compound 3: middle estimate off by 1.7-fold (0.24 log units), on the low side; measured number inside the range.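

On the aromatic carbon next to the ring oxygen, the group decides whether growth inhibition can be read as a number at all: in this assay, ethyl in place of phenyl gives an at least 3.8-fold lower number from compound 2 to compound 3 (0.58 log units; beyond the scatter). A ring is therefore not needed at this carbon for measurable inhibition of growth. Compound 2 stands at a limit of the assay, so this step gives only a minimum size: the limit of > 10000 nM in this assay, at which 1 of the 3 values shown sits. The compounds shown leave open how a methyl, a longer chain or an amine on this carbon would read in this assay.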